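Fluoro for bromo on compound 2: cytotoxicity notes

A few compounds are considered here, and "the series" means these few. Any claim that something is new, unique, unknown or untested is made for them only; others in the source may bear on it.

Measured compounds:
compound 1 `COc1nc2ccc(Br)cc2cc1C(c1ccccc1)n1cc(-c2ccccc2F)nn1` — 3.97%
compound 2 `COc1nc2ccc(Br)cc2cc1C(c1ccccc1)n1cc(-c2ccc(Br)cc2)nn1` — 6.28%
compound 3 `COc1nc2ccc(Br)cc2cc1C(c1ccccc1)n1cc(CCCO)nn1` — 27.4%

In an ADME assay on HEK293 cells (Homo sapiens) for cytotoxicity, read by sulforhodamine B assay, with a stated time of 48 h, tested at 10 uM (on this read-out higher numbers stand for more inhibition at the one concentration tested (going by the name of the read-out) and lower numbers for less inhibition), compound 1 gives 3.97%, compound 2 gives 6.28% and compound 3 gives 27.4%. Compound 2 stands second highest of the three numbers, but its nearest neighbour is compound 1: a number 2.3 percentage points higher from compound 1 to compound 2 (within the scatter), so the two aryl-bearing compounds cannot be told apart in this assay. Compound 3 is the only one set apart: a number 21.1 percentage points higher from compound 2 to compound 3 (beyond the scatter) and a number 23.4 percentage points higher from compound 1 to compound 3 (beyond the scatter), both modest and beyond the scatter, where a 3-hydroxypropyl takes the place of an aryl group.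

Compound 4 `COc1nc2ccc(Br)cc2cc1C(c1ccccc1)n1cc(-c2ccc(F)cc2)nn1` is the next step from compound 2: fluoro in place of bromo on an aromatic carbon. Among the compounds with values here, the step that bears on it most is the one from compound 1 to compound 2, a swap of one aryl group for another, which stayed within the scatter. The two steps that went beyond the scatter both involve the 3-hydroxypropyl of compound 3 and do not touch the change here. Compound 4 keeps an aryl group and only exchanges one halogen for another, so no step beyond the scatter is expected: a number 0.8 percentage points lower from compound 2 to compound 4 (within the scatter). Compound 4 is therefore estimated at 5.5%, with a range of -4% to 15% in this assay.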

Compound 4, a percentage reported as inhibition, at one concentration (the size of the read-out at that concentration, not a potency): 4.04%
The estimate for compound 4 lay 1.5 percentage points above the measured number; the range from low to high includes it.
By their numbers in this assay, from the lowest: compounds 1, 4 and 2 (each within the scatter of the next); then compound 3.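

Working notes: in this assay, fluoro in place of bromo on this aromatic carbon, para to a large group, gives a number 2.2 percentage points lower from compound 2 to compound 4 (within the scatter), and 4-fluorophenyl in place of 2-fluorophenyl gives a number 0.1 percentage points higher from compound 1 to compound 4 (within the scatter), so neither the identity of this halogen nor the two fluorophenyl arrangements can be told apart on this read-out. With a third aryl compound now in hand, 4-fluorophenyl in place of 3-hydroxypropyl gives a number 23.4 percentage points lower from compound 3 to compound 4 (beyond the scatter), which matches the separation already seen for compound 1 and compound 2 and leaves compound 3 alone above all three aryl compounds. No supporting measurement is available to account for either the flat aryl set or the separate position of compound 3.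

The compounds shown leave open whether the separation of compound 3 follows from the terminal hydroxyl or from the three-carbon chain itself, a question that a plain propyl, a longer chain ending in hydroxyl, or a chain ending in an amine or a carboxylic acid would bear on. They also leave open whether a phenyl ring carrying an amine would stay with the aryl set or move toward compound 3.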